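Sulfonyl-guanidine series: benzyl sulfide variation and cytotoxicity

The source may hold more compounds than are shown below. What is called first, only, known or untested is meant among the compounds shown, and "the series" means these compounds.

Measured so far:
compound 1 `Cc1cc(S(=O)(=O)/N=C(\N)n2nccc2-c2ccccc2)c(SCc2cccc(Cl)c2)cc1Cl`, 10000 nM
compound 2 `Cc1cc(-c2ccccc2)n(/C(N)=N/S(=O)(=O)c2cc(C)c(Cl)cc2SCc2cccc(C(F)(F)F)c2)n1`, 98000 nM
compound 3 `Cc1cc(-c2ccccc2)n(/C(N)=N/S(=O)(=O)c2cc(C)c(Cl)cc2SCc2cccc(Cl)c2)n1`, 8000 nM

Values come from a functional assay on HeLa cells (Homo sapiens) for cytotoxicity, read by MTT assay, with a stated time of 72 h; a lower number here means a stronger inhibitor, a higher number a weaker inhibitor. Compound 1 stands second highest of the three numbers; compound 3 sits nearest, and the step of a 1.3-fold lower number from compound 1 to compound 3 (0.10 log units; within the scatter) lies within the scatter. Compound 2 is furthest, with the highest number.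

Compound 4 `Cc1cc(S(=O)(=O)/N=C(\N)n2nccc2-c2ccccc2)c(SCc2cccc3ccccc23)cc1Cl` differs from compound 1 by naphthalen-1-yl in place of 3-chlorophenyl on a saturated chain carbon bound to a sulfur. Going by the values given here, no measured step covers this exact exchange. Among the compounds with values here, the only step touching the benzyl ring is a 12-fold lower number from compound 2 to compound 3 (1.09 log units; beyond the scatter), which shows that a change at this ring can move this assay strongly in either direction. Within the data shown here, with that precedent but no direct analogue, the expected step of no change at the digits printed from compound 1 to compound 4 (within the scatter) is modest and the range must be wide. Compound 4 is estimated at 10000 nM, between 2000 nM and 60000 nM.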

Compound 4, half-maximal inhibitory concentration: 3000 nM
Estimate against measurement, compound 4: 3.3-fold (0.52 log units) above; the measured number falls inside the stated range.
By their numbers in this assay, from the lowest: compound 4; then compounds 3 and 1 (each within the scatter of the next); then compound 2.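

In this assay, naphthalen-1-yl in place of 3-chlorophenyl gives a 3.3-fold lower number from compound 1 to compound 4 (0.52 log units; beyond the scatter) and so shows that this place on the saturated chain carbon bound to a sulfur accepts a second six-membered aromatic ring with a lower number. Going by these compounds alone, until now, the only step beyond the scatter at this ring was the exchange of trifluoromethyl for chloro in a 12-fold lower number from compound 2 to compound 3 (1.09 log units; beyond the scatter) and not a change of the ring itself. No supporting data bear on the origin of the step from compound 1 to compound 4.

The exchange adds a ring and removes the chloro group together, and the two remain unseparated. Going by these compounds, an unsubstituted phenyl, naphthalen-2-yl or pyridin-3-yl group at this place remains open.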